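A few compounds are considered here, and "the series" means these few. Any claim that something is new, unique, unknown or untested is made for them only; others in the source may bear on it.

Compound 1, `Cc1cc(C)nc(SCc2cc(=O)c3cc(Cl)ccc3o2)n1`, in a functional assay on LM7 cells (Homo sapiens) for cytotoxicity, read by MTT assay, with a stated time of 72 h (a lower number here means a stronger inhibitor, a higher number a weaker inhibitor), gives > 25000 nM, which is a limit of the assay. Compound 2, `Cc1nnc(SCc2cc(=O)c3cc(Cl)ccc3o2)o1`, in this assay gives > 25000 nM, likewise a limit of the assay.

Compound 1 thus has no number of its own in this assay: it sits at the limit of > 25000 nM in this assay, at which 2 of the 2 values shown sit, and compound 2 stands in the same place. Going by the values given here, the two measured compounds do not differ in a single position, so no step between them can be drawn, and nothing in these values orders the two compounds against each other. The unmeasured compound 3, `Cc1cc(C)nc(SCc2cc(=O)c3ccccc3o2)n1`, differs from compound 1 in one place: hydrogen in place of chloro on an aromatic carbon, in words hydrogen in place of chloro on an aromatic carbon. Among the compounds with values here, with both measured compounds resting at the limit, there is no measured step from which to take the size or direction of this change; the shared core is kept, and only the chloro is lost. The expected step that the limit leaves unreadable from compound 1 to compound 3 is none beyond the scatter. Compound 3 is therefore estimated at 40000 nM in this assay, with an expected range from 15000 nM to 100000 nM, most likely reported again only as a limit.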

Compound 3, half-maximal inhibitory concentration: > 25000 nM
Compound 3: only a limit was reported; the forecaster's own chance of this, stated with the estimate: 80%; the middle value is on the limit's open side.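

In this assay compound 3 gives > 25000 nM, a limit of the assay. Going by these compounds alone, no step from compound 1 to compound 3 can be read, so the size and direction of the exchange of chloro for hydrogen stay unknown: the limit of > 25000 nM in this assay, at which 3 of the 3 values shown sit. The compounds shown leave open which change, if any, would give a number rather than a limit in this assay.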